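Shortening the amine chains of compound 2

The source may hold more compounds than are shown below. What is called first, only, known or untested is meant among the compounds shown, and "the series" means these compounds.

Measured compounds: compound 1 `CCN(Cc1ccccc1)c1cccc(C(=O)N2CCc3ccc(OS(N)(=O)=O)cc3C2)c1` gives 69%; compound 2 `CC(C)CCN(CCC(C)C)c1ccc(C(=O)N2CCc3ccc(OS(N)(=O)=O)cc3C2)cc1` gives 90.8%; compound 3 `CC(C)CCN(CCC(C)C)c1cccc(C(=O)N2CCc3ccc(OS(N)(=O)=O)cc3C2)c1` gives 75.9%, all in an assay on HEK293 cells for inhibition of Steryl-sulfatase (Homo sapiens), tested at 1 uM; a lower number here means a weaker effect, a higher number a stronger effect of the compound at the concentration tested.

Compound 2 holds the highest number of the three, with compound 3 nearest and compound 1 furthest, both gaps beyond the scatter. Compound 4 `CCCN(CCC)c1ccc(C(=O)N2CCc3ccc(OS(N)(=O)=O)cc3C2)cc1` has not been measured; it differs from compound 2 by dipropylamino in place of diisopentylamino on an aromatic carbon. Going by the values given here, the only measured exchange of one amine for another, a number 6.9 percentage points higher from compound 1 to compound 3 (within the scatter), was within the scatter, but it concerns two larger amines and the shared core differs in where the amine sits. Weight is therefore given to the shorter chains of compound 4, and a modest drop is expected, a number 10.8 percentage points lower from compound 2 to compound 4 (beyond the scatter). Compound 4 is estimated at 80%, between 65% and 92%.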

Compound 4, a percentage reported as inhibition, at one concentration (the size of the read-out at that concentration, not a potency): 84.7%
For compound 4 the middle estimate is 4.7 percentage points below the measured one, within the range that was stated.
By their numbers in this assay, from the lowest: compounds 1, 3, 4 and 2 (each within the scatter of the next, the first and the last beyond it).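

In this assay, going by these compounds alone, the first exchange of one amine for another at this aromatic carbon, para to a large group, gives a number 6.1 percentage points lower from compound 2 to compound 4 (within the scatter). At this place, then, dipropylamino with 7 heavy atoms cannot be told apart from diisopentylamino with 11 heavy atoms, so the shorter chains cost nothing that this read-out can resolve. Nothing measured here bears on why the two chains read alike.

The compounds shown leave open how far the chains can shrink at this place, as with dimethylamino, and whether a chain ending in a carboxylic acid would be tolerated there.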